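The source may hold more compounds than are shown below. What is called first, only, known or untested is meant among the compounds shown, and "the series" means these compounds.

Compound 1 `CC1(C)[C@H]2CC[C@]1(C)N(Cc1cn(-c3ccc(Cl)cc3)nn1)C(=O)C2` gives 440 nM in a functional assay on PANC-1 cells (Homo sapiens) for inhibition, read by MTT assay, with a stated time of 24 h; on this read-out lower numbers stand for stronger inhibition and higher numbers for weaker inhibition.
Compound 2 `CC1(C)[C@H]2CC[C@]1(C)N(Cc1cn(-c3ccc(C#N)cc3)nn1)C(=O)C2` gives 250 nM in this assay.

Among these two numbers compound 2 has the lowest, with compound 1 its nearest neighbour, and the step of a 1.8-fold lower number from compound 1 to compound 2 (0.25 log units; within the scatter) lies within the scatter, so the two compounds cannot be ordered on these data. Compound 3 `CC1(C)[C@H]2CC[C@]1(C)N(Cc1cn(-c3cccc(C#N)c3)nn1)C(=O)C2` has not yet been measured. Compared with compound 2 the change is 3-cyanophenyl in place of 4-cyanophenyl on an aromatic nitrogen. Among the measured compounds shown here, no measured step involves a move of a substituent around the phenyl ring; the only step available, the change of cyano for chloro from compound 1 to compound 2, was small, and it speaks to the identity of the group rather than to where it sits. For the move of the nitrile in compound 3 there is therefore no direct guide, and the shift a 1.2-fold higher number from compound 2 to compound 3 (0.08 log units; within the scatter) is expected to stay within the scatter in either direction. Compound 3 is estimated to give 300 nM in this assay, within a range from 120 nM to 800 nM.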

Compound 3, half-maximal inhibitory concentration: 260 nM
Compound 3: middle estimate off by 1.2-fold (0.06 log units), on the high side; the measured number falls inside the stated range.
By their numbers in this assay, from the lowest: compounds 2, 3 and 1 (each within the scatter of the next).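

Among the compounds shown here, the position of the nitrile on the phenyl ring, a variable that the earlier compounds did not touch, makes no readable difference in this assay: the move from 4-cyanophenyl to 3-cyanophenyl on the aromatic nitrogen of the five-membered ring gives a 1.0-fold higher number from compound 2 to compound 3 (0.02 log units; within the scatter), so the two placements cannot be told apart. Replacing 4-chlorophenyl with 3-cyanophenyl, which changes both the substituent and where it sits, gives a 1.7-fold lower number from compound 1 to compound 3 (0.23 log units; within the scatter), so even this combined change does not separate the compounds, and all three remain one group on these data. No independent information bears on why this position responds so little.

The three compounds cover only chloro and nitrile substituents at these ring places, so they cannot show whether this flat picture would hold for a carboxylic acid, an amine or a methoxy group on the phenyl ring. Going by these compounds, it also remains open whether the number would stay in this range if a longer alkyl chain took the place of the phenyl ring on the aromatic nitrogen, or if the phenyl ring carried no substituent at all.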